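A few compounds are considered here, and "the series" means these few. Any claim that something is new, unique, unknown or untested is made for them only; others in the source may bear on it.

Measured so far in an ADME assay on microsomes from liver (Rattus norvegicus) for metabolic stability, with a stated time of 10 min; a lower number here means that less of the compound is left, a higher number that more of the compound is left:
compound 1 `CC(C)(C)OC(=O)NCCS(=O)(=O)NC(=O)c1ccc(Nc2nc(NC3(c4ccc(Cl)cc4)CC3)nc(OCC(F)(F)F)n2)cc1`, 93%;
compound 2 `CNC(=O)NCCS(=O)(=O)NC(=O)c1ccc(Nc2nc(NC3(c4ccc(Cl)cc4)CC3)nc(OCC(F)(F)F)n2)cc1`, 100%.

Compound 2 and compound 1 lie within the scatter of each other, so neither can be ranked above the other; both show most of the compound still present after the stated time. Compound 3 `O=C(NS(=O)(=O)CCNCc1ccccc1)c1ccc(Nc2nc(NC3(c4ccc(Cl)cc4)CC3)nc(OCC(F)(F)F)n2)cc1` differs from compound 2 by benzyl in place of methylcarbamoyl on an amine nitrogen. Among the compounds with values here, the only measured step, a number 7 percentage points higher from compound 1 to compound 2 (within the scatter), changed a group at a different spot and stayed within the scatter, so it gives little guidance for this new change. A moderate drop is expected: a number 22 percentage points lower from compound 2 to compound 3 (beyond the scatter). Compound 3 is therefore estimated at 78%, with a range from 50% to 100%.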

Compound 3, percent of the compound remaining: 100%
Estimate against measurement, compound 3: 22 percentage points below; measured number inside the range.
By their numbers in this assay, from the lowest: compounds 1, 2 and 3 (each within the scatter of the next).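

In this assay, benzyl in place of methylcarbamoyl on this amine nitrogen gives no change at the digits printed from compound 2 to compound 3 (within the scatter), and benzyl in place of tert-butoxycarbonyl gives a number 7 percentage points higher from compound 1 to compound 3 (within the scatter). So this position accepts a group with a six-membered aromatic ring and no hydrogen-bond donor or acceptor, as well as the two carbonyl-containing groups, without a difference beyond the scatter. No measured information accounts for this result.

Still open, going by these compounds, is whether a carboxylic acid or a longer chain on this nitrogen would also stay within the scatter. The same question applies to a second benzyl on it.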